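From methoxy to chloro in a cell growth test

A few compounds are considered here, and "the series" means these few. Any claim that something is new, unique, unknown or untested is made for them only; others in the source may bear on it.

Measured in a functional assay on MDA-MB-231 cells (Homo sapiens) for antiproliferative activity, read by spectrophotometry and resazurin assay, with a stated time of 72 h; a lower number here means a stronger inhibitor, a higher number a weaker inhibitor:
- Compound 1 `Cc1ccc(C(=O)CC2Oc3cc(O)ccc3C=C2c2ccc(O)cc2)cc1`: 55000 nM
- Compound 2 `COc1ccc(C(=O)CC2Oc3cc(O)ccc3C=C2c2ccc(O)cc2)cc1`: 7600 nM

Compound 2 has the lower of the two numbers, at 7600 nM. Compound 3 `O=C(CC1Oc2cc(O)ccc2C=C1c1ccc(O)cc1)c1ccc(Cl)cc1` carries chloro in place of methoxy on an aromatic carbon. Going by the values given here, one measured step bears on this change: a 7.2-fold lower number from compound 1 to compound 2 (0.86 log units; beyond the scatter), which came with methoxy in place of methyl. Among the compounds with values here, no measured compound yet carries chloro, so a smaller step towards a higher number is expected in this assay. The expected change is a 2.6-fold higher number from compound 2 to compound 3 (0.42 log units; beyond the scatter). For compound 3 the estimate is 20000 nM, with an expected range of 6000 nM to 60000 nM.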

Compound 3, half-maximal inhibitory concentration: 151000 nM
Beside the measured number, compound 3's estimate is 7.6-fold (0.88 log units) below it, and the stated range ends below it.
By their numbers in this assay, from the lowest: compound 2; then compound 1; then compound 3.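

Chloro gives the weakest result of the three groups at this position, para to a large group, in (this assay): compound 3 falls well behind compound 2 (a 20-fold higher number from compound 2 to compound 3 (1.30 log units; beyond the scatter)) and also behind compound 1 (a 2.7-fold higher number from compound 1 to compound 3 (0.44 log units; beyond the scatter)). The order is therefore methoxy, then methyl, then chloro, so the loss on leaving methoxy depends strongly on the group that enters. No measurement at hand explains this order. Still open, on these data alone, is how an amine, a carboxylic acid or a longer chain such as ethoxy would compare with methoxy at this position.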